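A few compounds are considered here, and "the series" means these few. Any claim that something is new, unique, unknown or untested is made for them only; others in the source may bear on it.

For the measured compounds named here, in a functional assay on CCRF-CEM cells (Homo sapiens) for inhibition, read by MTT assay, with a stated time of 72 h (on this read-out lower numbers stand for stronger inhibition and higher numbers for weaker inhibition), compound 3 (`COc1cc(NC(C)CCCNC(=O)NNC(=O)Nc2ccc(Br)cc2)c2ncccc2c1`) gives 110000 nM, the highest of the three numbers so far. Compound 1 (`COc1cc(NC(C)CCCNC(=O)Nc2ccc(Br)cc2)c2ncccc2c1`) gives 23000 nM, and compound 2 (`COc1cc(NC(C)CCCNC(=O)NNC(=O)Nc2ccc(C(F)(F)F)cc2)c2ncccc2c1`) gives 18000 nM. Compound 4 (`COc1cc(NC(C)CCCNC(=O)NNC(=O)Nc2cccc(F)c2)c2ncccc2c1`) carries 3-fluorophenyl in place of 4-bromophenyl on an amide-type nitrogen. Going by the values given here, the nearest precedent is the modest 6.1-fold higher number from compound 2 to compound 3 (0.79 log units; beyond the scatter), with bromo in place of trifluoromethyl on an aromatic carbon. The also modest a 4.8-fold higher number from compound 1 to compound 3 (0.68 log units; beyond the scatter) concerns a different change and bears only weakly. Among the compounds with values here, no measured compound carries 3-fluorophenyl, so a modest move to a lower number is expected in this assay. The expected step is a 2.4-fold lower number from compound 3 to compound 4 (0.39 log units; beyond the scatter). The estimate for compound 4 is 45000 nM, with an expected range of 15000 nM to 120000 nM.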

Compound 4, half-maximal inhibitory concentration: 98000 nM
The estimate for compound 4 lay 2.2-fold (0.34 log units) below the measured number; the range from low to high includes it.
By their numbers in this assay, from the lowest: compounds 2 and 1 (each within the scatter of the next); then compounds 4 and 3 (each within the scatter of the next).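

In this assay, 3-fluorophenyl in place of 4-bromophenyl on this amide-type nitrogen leaves the read-out within the scatter, with a 1.1-fold lower number from compound 3 to compound 4 (0.05 log units; within the scatter). Compound 2 therefore stays apart from a second aryl variant, with a 5.4-fold higher number from compound 2 to compound 4 (0.74 log units; beyond the scatter), and the shorter compound 1 also keeps its gap, with a 4.3-fold higher number from compound 1 to compound 4 (0.63 log units; beyond the scatter). No measurement bears on the reason for these steps. The halogen and its ring position change together here, so their separate contributions stay unresolved. On these data alone, whether 4-fluorophenyl or 4-cyanophenyl would track compound 2 or compound 3 remains open.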